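The source may report more compounds than this note shows. Statements on the series, on what has been measured and on what is new or still open speak of the compounds shown alone.

Three compounds have been measured in an ADME assay on microsomes from liver (Homo sapiens) for metabolic stability, tested at 2.5 uM; a higher number here means faster removal of the compound, a lower number slower removal:

Compound 1 `Brc1cccc2c1nnn2CC1CCC1` gives 8.7 mL/min/g.
Compound 2 `Brc1cccc2c1nnn2CC1CC1` gives 1.3 mL/min/g.
Compound 3 `CCCn1nnc2c(Br)cccc21` gives 4.7 mL/min/g.

Compound 2 stands lowest of the three. The step of a 6.7-fold lower number from compound 1 to compound 2 (0.83 log units; beyond the scatter) is the largest gap in the set, and a 3.6-fold higher number from compound 2 to compound 3 (0.56 log units; beyond the scatter) also lies beyond the scatter, whereas a 1.9-fold lower number from compound 1 to compound 3 (0.27 log units; within the scatter) stays within it. All three measured steps concern the saturated chain carbon bound to an aromatic nitrogen.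

Compound 4 `FC(F)(F)c1cc(Br)c2nnn(CC3CC3)c2c1` differs from compound 2 in another place: trifluoromethyl in place of hydrogen on an aromatic carbon. Within the data shown here, none of the measured steps touches the six-membered aromatic ring of carbon only, so the data give no direct guide for this change. With nothing in the measured steps to move the number, compound 4 is expected to stay close to compound 2, and the step of a 1.1-fold lower number from compound 2 to compound 4 (0.03 log units; within the scatter) is estimated to fall within the scatter. Compound 4 is therefore estimated at 1.2 mL/min/g, with a range from 0.4 mL/min/g to 3.6 mL/min/g.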

Compound 4, intrinsic clearance in a liver preparation (reported as CLH), per the amount of preparation that the assay uses: 0.1 mL/min/g
For compound 4 the middle estimate is 12-fold (1.08 log units) above the measured one; measured number below the stated range.
By their numbers in this assay, from the lowest: compound 4; then compound 2; then compounds 3 and 1 (each within the scatter of the next).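

In this assay, trifluoromethyl in place of hydrogen on an aromatic carbon, meta to a bromo group and para to a fused ring, gives a 13-fold lower number from compound 2 to compound 4 (1.11 log units; beyond the scatter) and so places compound 4 lowest of the four. Among these compounds, all the earlier steps concerned the saturated chain carbon bound to an aromatic nitrogen, so this is the first sign that a change on the six-membered aromatic ring of carbon only can also move the number, here by a large step. No measurement shown here accounts for this step.

The compounds shown leave open whether a fluoro group, a methoxy group or a nitrile on this same carbon would give a similar number. They also leave open whether trifluoromethyl would give a step of this size with the cyclobutyl or ethyl groups of compound 1 and compound 3.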